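Swapping a methylphenyl arm for a pyridine ring

This account rests on a few compounds, and the source may have more. Where it says the series, first, only, none or still open, it means among the compounds named here.

Compound 1, `Cc1cccc(-c2cc(-c3ccc(Cl)o3)cc(-c3ccsc3)n2)c1`, and compound 2, `Clc1cccc(-c2cc(-c3ccc(Cl)o3)cc(-c3cccs3)n2)c1`, are built on the same core and carry a 5-chlorofuran-2-yl group, differing only in their remaining arms. In a functional assay on HCT-15 cells (Homo sapiens) for cytotoxicity, in the presence of a further agent that is not named here (on this read-out lower numbers stand for stronger inhibition and higher numbers for weaker inhibition), compound 1 gives 21700 nM, the higher of the two numbers recorded so far. Compound 2 gives 15500 nM in this assay. These two values lie within the usual scatter of repeated measurements, so neither compound can be called the stronger inhibitor; both inhibit only weakly.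

Compound 3, `Clc1ccc(-c2cc(-c3ccsc3)nc(-c3ccccn3)c2)o1`, has not yet been measured. It differs from compound 1 at a single aromatic carbon of the core: pyridin-2-yl in place of 3-methylphenyl on an aromatic carbon. Among the measured compounds shown here, no pair of measured compounds shows what such a replacement does here, and the two measured values themselves span no more than the scatter, so there is nothing to point in either direction. The expected step is therefore a 1.1-fold lower number from compound 1 to compound 3 (0.06 log units; within the scatter), which amounts to no change beyond the scatter. Compound 3 is estimated at 19000 nM in this assay, with a range from 6000 nM to 55000 nM.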

Compound 3, half-maximal inhibitory concentration: > 50000 nM
Compound 3: only a limit was reported; the forecaster's own chance of this, stated with the estimate: 15%; at least 2.6-fold (0.42 log units) between middle value and limit.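

Among the compounds shown here, this is the first single change read at this position, on the aromatic carbon next to the ring nitrogen, and it moves the result: in this assay, pyridin-2-yl in place of 3-methylphenyl gives an at least 2.3-fold higher number from compound 1 to compound 3 (0.36 log units; beyond the scatter). In this one pair, then, exchanging a carbon-only ring for a ring with one nitrogen weakens inhibition beyond the scatter, even though compound 1 was already only a weak inhibitor. The result for compound 3 is a limit of the assay and not a number, so the step shows a direction and a minimum size, while its full size stays unknown: the limit of > 50000 nM in this assay, at which 1 of the 3 values shown sits.

The step removes the methyl group and adds the ring nitrogen together, and this pair cannot separate the two. The compounds shown also leave open how a plain phenyl ring, or a phenyl ring carrying an amine or a carboxylic acid, would behave at this position, and whether any arm placed here could give stronger inhibition than compound 1.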